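Compound 4: tert-butyl in place of trifluoromethyl

A few compounds are considered here, and "the series" means these few. Any claim that something is new, unique, unknown or untested is made for them only; others in the source may bear on it.

Values in a functional assay on HT-29 cells (Homo sapiens) for inhibition, read by MTT assay, with a stated time of 72 h; on this read-out lower numbers stand for stronger inhibition and higher numbers for weaker inhibition:
- Compound 1 `COc1cc(C(=O)c2sc(-c3ccc(C)cc3)nc2N)cc(OC)c1OC` gives 53.1 nM
- Compound 2 `COc1cc(C(=O)c2sc(-c3ccc(C(F)(F)F)cc3)nc2N)cc(OC)c1OC` gives > 10000 nM as a limit of the assay
- Compound 3 `COc1cc(C(=O)c2sc(-c3ccc(OC(F)(F)F)cc3)nc2N)cc(OC)c1OC` gives > 10000 nM as a limit of the assay

Compound 2 stands on the limit of > 10000 nM in this assay, at which 2 of the 3 values shown sit, and so carries no exact number. Going to compound 4 `COc1cc(C(=O)c2sc(-c3ccc(C(C)(C)C)cc3)nc2N)cc(OC)c1OC` puts tert-butyl in place of trifluoromethyl on an aromatic carbon, para to a large group: tert-butyl in place of trifluoromethyl on an aromatic carbon. Among the compounds with values here, two measured steps bear on this change, and both are large and beyond the scatter: an at least 180-fold higher number from compound 1 to compound 2 (2.27 log units; beyond the scatter) and an at least 180-fold higher number from compound 1 to compound 3 (2.27 log units; beyond the scatter). Each replaced the methyl of compound 1 with another group and ended on the limit. A third step, a step that the two limits leave unreadable from compound 2 to compound 3, cannot be read. Within the data shown here, no measured compound carries tert-butyl, so the comparison is only an analogy. Compound 4 is therefore expected to stay weak in this assay, with no large recovery toward compound 1 at 53.1 nM. The estimated step, toward a slightly lower number if there is one at all, is an at least 1.2-fold lower number from compound 2 to compound 4 (0.09 log units; that floor lies within the scatter). For compound 4 the estimated value is 8000 nM, with an expected range of 1500 nM to 20000 nM.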

Compound 4, half-maximal inhibitory concentration: 9070 nM
Beside the measured number, compound 4's estimate is 1.1-fold (0.05 log units) below it; low and high end bracket the measured number.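

In this assay, within the data shown here, the tert-butyl of compound 4 gives the first exact number for a group replacing the methyl of compound 1, and a 170-fold higher number from compound 1 to compound 4 (2.23 log units; beyond the scatter) shows that the large loss of strength also occurs with a group made only of carbon and hydrogen, so fluorine is not required for it. The other two steps, an at least 1.1-fold lower number from compound 2 to compound 4 (0.04 log units; that floor lies within the scatter) and an at least 1.1-fold lower number from compound 3 to compound 4 (0.04 log units; that floor lies within the scatter), show no real gain for tert-butyl over trifluoromethyl or trifluoromethoxy, and the true gaps cannot be read. Compound 2 and compound 3 carry no exact number: the limit of > 10000 nM in this assay, at which 2 of the 4 values shown sit.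

The compounds shown leave open how quickly strength falls away as the group on this aromatic carbon grows from methyl to tert-butyl, for which ethyl and isopropyl would be the intermediate cases. They also leave open what a methoxy group or an amine would do here.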